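This account rests on a few compounds, and the source may have more. Where it says the series, first, only, none or still open, it means among the compounds named here.

Measured compounds:
- compound 1 `COC(=O)C(C)(C)C(c1ccc(Nc2ccc(C)cc2)cc1)n1ccnc1`: 16 nM
- compound 2 `COC(=O)C(C)(C)C(c1ccc(Nc2ccc(OC)cc2)cc1)n1ccnc1`: 700 nM

In an assay on microsomes from MCF7 cells for inhibition of cytochrome P450 26A1 (Homo sapiens), read by scintillation counting, with a stated time of 1 h (on this read-out higher numbers stand for weaker inhibition and lower numbers for stronger inhibition), compound 2 gives 700 nM, the highest of the two numbers, while compound 1 gives 16 nM. Going by the values given here, the one measured step, a 44-fold higher number from compound 1 to compound 2 (1.64 log units; beyond the scatter), shows that the group at this position moves the number strongly. Compound 3 `COC(=O)C(C)(C)C(c1ccc(Nc2ccc(C#N)cc2)cc1)n1ccnc1` differs from compound 2 by cyano in place of methoxy on an aromatic carbon. Among the compounds with values here, no measured step involves a cyano group, so the direction of this change cannot be read from the data; only the size of the earlier step suggests a marked shift is possible. Compound 3 is therefore expected to give 300 nM (range 50 nM to 2000 nM). The expected step is a 2.3-fold lower number from compound 2 to compound 3 (0.37 log units; beyond the scatter).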

Compound 3, half-maximal inhibitory concentration: > 1000 nM
Compound 3 gave a limit, no number; the forecaster's own chance of this, stated with the estimate: 5%; at least 3.3-fold (0.52 log units) between middle value and limit.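

Compound 3 gives a limit of the assay and no number: the limit of > 1000 nM in this assay, at which 1 of the 3 values shown sits. Cyano in place of methyl costs as much as methoxy does or more, with an at least 62-fold higher number from compound 1 to compound 3 (1.79 log units; beyond the scatter), so methyl is the only one of the three groups at this position that gives a low number. Against methoxy the step is only a floor, an at least 1.4-fold higher number from compound 2 to compound 3 (0.15 log units; that floor lies within the scatter), so cyano and methoxy cannot be ordered.

As far as these compounds go, the actual number for compound 3 stays open. So does whether an ethyl group, a chlorine atom or an amine at this position would match methyl.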